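Removing the benzyloxy group from compound 2

The source may report more compounds than this note shows. Statements on the series, on what has been measured and on what is new or still open speak of the compounds shown alone.

Among the compounds with values here, in a functional assay on MOLT-4 cells (Homo sapiens) (a higher number here means a weaker inhibitor, a lower number a stronger inhibitor), compound 2 (`COc1cc(NC(C)CCCNC(=O)NOCc2ccccc2)c2ncccc2c1`) gives 12000 nM as the only true number in this small set. Compound 1 (`COc1cc(NC(C)CCCNC(=O)NCCCO)c2ncccc2c1`) gives > 100000 nM as a limit of the assay and not a number. Compound 3 (`COc1cc(N2C(=O)NCCCC2C)c2ncccc2c1`) gives >= 100000 nM as a limit of the assay and not a number.

The next compound to be measured is compound 4 (`COC(=O)NCCCC(C)Nc1cc(OC)cc2cccnc12`). The change is methoxy in place of (benzyloxy)amino on a carbonyl carbon and in words it puts methoxy in place of (benzyloxy)amino on a carbonyl carbon.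

Within the data shown here, one measured step bears on this change. It is an at least 8.3-fold lower number from compound 1 to compound 2 (0.92 log units; beyond the scatter) and it lies beyond the scatter, with benzyloxy in place of 3-hydroxypropyl on an amide-type nitrogen. That step is not the same change, and its size is known only as a bound, so it serves as a guide and not as a measure. Compound 1 and compound 3 both lack the benzyloxy group and both sit at a limit, and compound 4 lacks it too. In this assay a move toward a weaker inhibitor is therefore expected, with an estimated 4.2-fold higher number from compound 2 to compound 4 (0.62 log units; beyond the scatter) as the step. For compound 4 the estimated value is 50000 nM within an expected range of 15000 nM to 150000 nM and a report as a limit alone would be no surprise.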

Compound 4, half-maximal inhibitory concentration: > 100000 nM
Compound 4 was reported as a limit; the forecaster's own chance of this, stated with the estimate: 50%; middle value at least 2.0-fold (0.30 log units) from the limit.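

In this assay, methoxy in place of (benzyloxy)amino on a carbonyl carbon gives an at least 8.3-fold higher number from compound 2 to compound 4 (0.92 log units; beyond the scatter), a step beyond the scatter whose size is known only as a bound. Within the data shown here, the earlier step altered the group on an amide-type nitrogen, whereas this one removes that nitrogen together with the benzyloxy group and its six-membered aromatic ring of carbon only, and the only true number in the set still belongs to compound 2, the one compound of the four that carries benzyloxy. Compound 4 is reported only as a limit, the same limit as most of the set, so the loss on this carbonyl carbon has a lower bound but no measured end: the limit of > 100000 nM in this assay, at which 2 of the 4 values shown sit.

From the compounds shown here alone, the step from compound 1 to compound 4 cannot be read, as both values are limits, and the order among the compounds without benzyloxy stays unknown. Going by these compounds, it also remains open which part of (benzyloxy)amino matters: methoxyamino would keep the nitrogen and oxygen without the aromatic ring, and benzylamino would keep the aromatic ring without the oxygen.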